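The source may report more compounds than this note shows. Statements on the series, on what has been measured and on what is new or still open speak of the compounds shown alone.

Compound 1 `Oc1ccc(-c2cc(-c3cccc(C(F)(F)F)c3)cc(-c3cccc(O)c3)n2)cc1` gives 11100 nM in a functional assay on DU-145 cells (Homo sapiens) for inhibition; on this read-out lower numbers stand for stronger inhibition and higher numbers for weaker inhibition.
Compound 2 `Oc1ccc(-c2cc(-c3ccc(C(F)(F)F)cc3)cc(-c3cccc(O)c3)n2)cc1` gives in this assay only a limit of the assay, > 50000 nM.
Compound 3 `Oc1ccc(-c2cc(-c3cccc(C(F)(F)F)c3)cc(-c3ccc(O)cc3)n2)cc1` gives in this assay likewise only a limit of the assay, > 50000 nM.

Compound 4 `Oc1ccc(-c2cc(-c3ccc(C(F)(F)F)cc3)cc(-c3ccc(O)cc3)n2)cc1` has not yet been measured. All four share one core carrying three aryl groups. The cores of compound 1 and compound 3 differ by 4-hydroxyphenyl in place of 3-hydroxyphenyl on an aromatic carbon, a change that made an at least 4.5-fold higher number from compound 1 to compound 3 (0.65 log units; beyond the scatter).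

The change now in question, (4-(trifluoromethyl)phenyl in place of 3-(trifluoromethyl)phenyl on an aromatic carbon), was made once among the measured compounds, where it made an at least 4.5-fold higher number from compound 1 to compound 2 (0.65 log units; beyond the scatter). Its true size is known only as a lower bound because of the limit of > 50000 nM in this assay, at which 2 of the 3 values shown sit. From compound 3 to compound 4 the change is 4-(trifluoromethyl)phenyl in place of 3-(trifluoromethyl)phenyl on an aromatic carbon. It is the same kind of change, not the same one: in the earlier pair the group sits meta to a 3-hydroxyphenyl group and meta to a 4-hydroxyphenyl group, whereas in the new pair it sits meta to two 4-hydroxyphenyl groups, opposite the ring nitrogen in both cases.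

Compound 3 already stands at a limit of the assay, > 50000 nM. Given that starting point, and given an at least 4.5-fold higher number from compound 1 to compound 2 (0.65 log units; beyond the scatter), compound 4 is expected to move by about a step that the limit leaves unreadable from compound 3 to compound 4, which would leave it at the limit as well. The estimate for compound 4 in this assay is 100000 nM, within a range from 30000 nM to 400000 nM, and most probably the assay will again report only a limit.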

Compound 4, half-maximal inhibitory concentration: > 50000 nM
Compound 4 gave a limit, no number; the forecaster's own chance of this, stated with the estimate: 90%; the middle value does not contradict the limit.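

Compound 4 gives only a limit in this assay, so the steps from compound 3 to compound 4 and from compound 2 to compound 4 cannot be read, because neither pair has a number at both ends: the limit of > 50000 nM in this assay, at which 3 of the 4 values shown sit.

As far as these compounds go, whether 4-(trifluoromethyl)phenyl in place of 3-(trifluoromethyl)phenyl changes inhibition when the core carries two 4-hydroxyphenyl groups stays open, as does any order among compound 2, compound 3 and compound 4.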